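Ester group swap from compound 1 to compound 4

The compounds below may be only part of what the source reports. "The series", "measured", "known", "first", "only" and "open" are said of these compounds alone.

Among the measured compounds shown here, in an ADME assay on RAW264.7 cells (Mus musculus) for cytotoxicity, read by MTT assay, with a stated time of 24 h (on this read-out higher numbers stand for lower toxicity in this test and lower numbers for higher toxicity in this test), compound 1 (`CC/C=C\C[C@H]1C(=O)C=C[C@H]1CC(=O)Oc1ccc(O)cc1`) gives 49 uM, the lowest of the three numbers so far. Compound 2 (`CC/C=C\C[C@H]1C(=O)C=C[C@H]1CC(=O)Oc1ccccc1OC`) gives 161 uM and compound 3 (`CC/C=C\C[C@H]1C(=O)C=C[C@H]1CC(=O)OCCOCCOCCOC`) gives 163 uM. Those two values lie within the scatter of each other, and both lie beyond the scatter from compound 1.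

Compound 4 (`CC/C=C\C[C@H]1C(=O)C=C[C@H]1CC(=O)OC(C)COC`) is still unmeasured. It carries 1-(methoxymethyl)ethyl in place of 4-hydroxyphenyl on an oxygen next to a carbonyl group.

For the measured compounds named here, no measured pair differs in one place, so the expectation rests on comparison alone. The nearest guide is compound 3, which also has no ring in the group on that oxygen and gives 163 uM. Compound 2 keeps an aromatic ring and still gives 161 uM, so a ring alone does not separate the values.

The expected change is an upward step beyond the scatter, a 2.9-fold higher number from compound 1 to compound 4 (0.46 log units; beyond the scatter). The estimated value for compound 4 is 140 uM, with an expected range of 70 uM to 280 uM.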

Compound 4, half-maximal toxic concentration: 161 uM
Compound 4: the middle estimate sits 1.2-fold (0.06 log units) below what was measured, within the range that was stated.
By their numbers in this assay, from the lowest: compound 1; then compounds 2, 4 and 3 (each within the scatter of the next).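

In this assay, among the compounds shown here, 1-(methoxymethyl)ethyl in place of 4-hydroxyphenyl on an oxygen next to a carbonyl group gives a 3.3-fold higher number from compound 1 to compound 4 (0.52 log units; beyond the scatter), the first step at this position that can be read from a change in one place. The step removes the aromatic ring and the hydrogen-bond donor together, and nothing shown separates those two changes or gives a reason for the step.

Compound 4 at 161 uM lies within the scatter of compound 2 and compound 3, so three different groups on this oxygen share one level, and compound 1 alone stands apart from it.

An unsubstituted phenyl on this oxygen would show whether the hydroxy group of compound 1 or its ring goes with the lower number. On these data alone, how a longer chain carrying an amine or a carboxylic acid would read in this assay remains open.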